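Aryl change from compound 2 to compound 3

This account rests on a few compounds, and the source may have more. Where it says the series, first, only, none or still open, it means among the compounds named here.

In a functional assay on HeLa cells (Homo sapiens) for cytotoxicity, read by MTT assay, with a stated time of 24 h (on this read-out higher numbers stand for weaker inhibition and lower numbers for stronger inhibition), compound 1 `COc1cc(/C=C2\CN(C)C/C(=C\c3ccc(Cl)c(Cl)c3)C2=O)cc(OC)c1OC` gives 13500 nM. Compound 2 `CN1C/C(=C\c2ccc(Cl)cc2)C(=O)/C(=C/c2cccc([N+](=O)[O-])c2)C1` gives > 20000 nM, which is a limit of the assay and not a number. Compound 3 `CN1C/C(=C\c2cccc(Br)c2)C(=O)/C(=C/c2cccc([N+](=O)[O-])c2)C1` differs from compound 2 by 3-bromophenyl in place of 4-chlorophenyl on a double-bonded chain carbon bound to a double-bonded ring carbon, with 3-bromophenyl in place of 4-chlorophenyl on a double-bonded chain carbon bound to a double-bonded ring carbon. Among the compounds with values here, no measured step covers this change. The step expected in this assay is none beyond the scatter, in either direction. Compound 3 is expected near 22000 nM, with an estimated range of 10000 nM to 60000 nM.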

Compound 3, half-maximal inhibitory concentration: 11100 nM
Compound 3: the middle estimate sits 2.0-fold (0.30 log units) above what was measured, within the range that was stated.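

At this position, on a double-bonded chain carbon bound to a double-bonded ring carbon, 3-bromophenyl in place of 4-chlorophenyl gives an at least 1.8-fold lower number from compound 2 to compound 3 (0.25 log units; that floor lies within the scatter) in this assay. Compound 2 gives > 20000 nM, a limit of the assay and not a number. The step is only a floor, and its full size cannot be read, because it starts from that limit: the limit of > 20000 nM in this assay, at which 1 of the 3 values shown sits.

Halogen and ring position change together here, so the compounds shown do not separate the two; 3-chlorophenyl would. As far as these compounds go, how an amine or a carboxylic acid on this phenyl ring would read also stays open.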